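Ethyl to methylsulfonyl on a weak pyrimidine analogue

The source may hold more compounds than are shown below. What is called first, only, known or untested is meant among the compounds shown, and "the series" means these compounds.

Measured compounds:
compound 1, `OCc1ccc(-c2nn(Cc3ccccc3F)c3ncccc23)o1`, 1700 nM; 1700 nM (2 entries)
compound 2, `NS(=O)(=O)c1ccc(-c2nn(Cc3ccccc3F)c3ncccc23)o1`, 8000 nM
compound 3, `CCc1cnc(-c2nn(Cc3ccccc3F)c3ncccc23)nc1N`, 272000 nM

In a functional assay (aorta) with Oryctolagus cuniculus as the target (on this read-out higher numbers stand for weaker inhibition and lower numbers for stronger inhibition), compound 3 gives 272000 nM, the highest number among the measured compounds; compound 2 sits far below it, beyond the scatter, and compound 1 is the other entry. Compound 4, `CS(=O)(=O)c1cnc(-c2nn(Cc3ccccc3F)c3ncccc23)nc1N`, keeps the core of compound 3 and changes one group: methylsulfonyl in place of ethyl on an aromatic carbon. Among the measured compounds shown here, no measured pair of compounds makes this same change, so there is no step to lean on; what the data give is that a sulfur-bearing group on a different ring, in compound 2, stands above compound 1. Compound 4 is therefore expected to stay in the weak range of compound 3, with a step of a 1.8-fold lower number from compound 3 to compound 4 (0.26 log units; within the scatter) likely within or near the scatter. The estimate for compound 4 in this assay is 150000 nM, with a range from 30000 nM to 600000 nM.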

Compound 4, half-maximal inhibitory concentration: 261000 nM
Compound 4: middle estimate off by 1.7-fold (0.24 log units), on the low side; measured number inside the range.
By their numbers in this assay, from the lowest: compound 2; then compounds 4 and 3 (each within the scatter of the next).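

In this assay, methylsulfonyl in place of ethyl on this aromatic carbon, ortho to an amino group, gives a 1.0-fold lower number from compound 3 to compound 4 (0.02 log units; within the scatter) and so leaves the number within the scatter. Among the compounds shown here, this is the first comparison at this position, and it shows that two groups differing in heavy atoms and hydrogen-bond acceptors can give matching read-outs here. No measurement shown here offers an explanation for this match. On these data alone, whether an amine, a carboxylic acid or a longer chain at this position would move the number out of this weak range remains open.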